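Double-bond geometry and antiproliferative potency in the series

The source may hold more compounds than are shown below. What is called first, only, known or untested is meant among the compounds shown, and "the series" means these compounds.

Measured so far:
compound 1, `CCCCCCCCC#Cc1cn(C/C=C\CN2C(=O)c3ccccc3C2=O)c(=O)[nH]c1=O`: 64000 nM
compound 2, `O=C1c2ccccc2C(=O)N1C/C=C\Cn1cc(C#Cc2ccc(Br)cc2)c(=O)[nH]c1=O`: > 100000 nM
compound 3, `O=C1c2ccccc2C(=O)N1C/C=C\Cn1cc(C#CCCc2ccccc2)c(=O)[nH]c1=O`: > 100000 nM

Among the compounds with values here, in a functional assay on MCF7 cells (Homo sapiens) for antiproliferative activity, read by MTT assay, with a stated time of 3 days (a lower number here means a stronger inhibitor, a higher number a weaker inhibitor), compound 1 gives 64000 nM, the only actual number among the three. For compound 2 the value > 100000 nM is a limit of the assay, not a number. For compound 3 the value > 100000 nM is likewise a limit. Two of three values thus sit at the limit of > 100000 nM in this assay, at which 2 of the 3 values shown sit, so compound 1 is the only anchor with a readable number. The steps of an at least 1.5-fold higher number from compound 1 to compound 2 (0.19 log units; that floor lies within the scatter) and an at least 1.5-fold higher number from compound 1 to compound 3 (0.19 log units; that floor lies within the scatter) both replace the group on the triple bond and are floor values within the scatter; the step that the two limits leave unreadable from compound 2 to compound 3 cannot be read.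

Compound 4, `CCCCCCCCC#Cc1cn(C/C=C/CN2C(=O)c3ccccc3C2=O)c(=O)[nH]c1=O`, differs from compound 1 as follows: the two compounds have the same atoms and bonds and differ only in configuration as drawn: 1 of 1 stereo elements differ; a double bond is drawn Z in compound 1 and E in compound 4. Within the data shown here, no measured step touches the double bond geometry, so none bears directly on this change. The expected step of no change at the digits printed from compound 1 to compound 4 (within the scatter) is therefore none beyond the scatter. Compound 4 is estimated at 64000 nM, with an expected range of 25000 nM to 160000 nM.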

Compound 4, half-maximal inhibitory concentration: 66000 nM
For compound 4 the middle estimate is 1.0-fold (0.01 log units) below the measured one; the range from low to high includes it.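

In this assay, drawing the double bond E rather than Z gives a 1.0-fold higher number from compound 1 to compound 4 (0.01 log units; within the scatter), so with octyl on the triple-bonded carbon the geometry of this double bond leaves no mark beyond the scatter. Within the data shown here, this is the first step with both ends readable as numbers, and the first that leaves the group on the triple bond untouched. Geometry is thus isolated as the single variable here: the fact that compounds 1 and 4 differ only in the configuration as drawn

Going by these compounds, whether the same holds with 4-bromophenyl or phenethyl on the triple bond stays open, as compound 2 and compound 3 each stand only at a limit of the assay: the limit of > 100000 nM in this assay, at which 2 of the 4 values shown sit. Also open is whether a longer chain or a carboxylic acid in place of octyl would bring out any difference between the Z and E forms.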